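Alpha-ketooxazole series: swapping the oxazole aryl substituent

A few compounds are considered here, and "the series" means these few. Any claim that something is new, unique, unknown or untested is made for them only; others in the source may bear on it.

Measured so far:
compound 1 `O=C(CCc1ccc(-c2ccccc2)cc1)c1ncc(-c2ccncc2)o1` — 2.3 nM
compound 2 `COC(=O)c1ccc(-c2cnc(C(O)CCc3ccc(-c4ccccc4)cc3)o2)nc1` — 1100 nM
compound 3 `CN(C)C(=O)c1cnc(C(=O)CCc2ccc(COc3ccccc3)cc2)o1` — 6.7 nM

In an assay for inhibition of Fatty-acid amide hydrolase 1 (Rattus norvegicus) (a lower number here means a stronger inhibitor, a higher number a weaker inhibitor), compound 1 gives the lowest of the three numbers; compound 3 stands nearest, compound 2 furthest, and both gaps lie beyond the scatter. Compound 4 `COC(=O)c1ccc(-c2cnc(C(=O)CCc3ccc(-c4ccccc4)cc3)o2)cn1` is not yet measured. It differs from compound 1 in one place: 6-(methoxycarbonyl)pyridin-3-yl in place of pyridin-4-yl on an aromatic carbon. The carbonyl and the biphenyl chain of compound 1 are kept. Among the compounds with values here, with no measured pair isolating this change, the step in this assay is expected to be small, at most a modest weakening, and may well fall within the scatter; the estimate is a 1.5-fold higher number from compound 1 to compound 4 (0.18 log units; within the scatter). Compound 4 is expected to give about 3.5 nM in this assay, within 1.2 nM to 12 nM.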

Compound 4, inhibition constant: 0.6 nM
The estimate for compound 4 lay 5.8-fold (0.77 log units) above the measured number, and the stated range ends above it.
By their numbers in this assay, from the lowest: compound 4; then compound 1; then compound 3; then compound 2.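

In this assay, the aromatic carbon next to the ring oxygen tolerates a larger group: 6-(methoxycarbonyl)pyridin-3-yl in place of pyridin-4-yl gives a 3.8-fold lower number from compound 1 to compound 4 (0.58 log units; beyond the scatter) and costs no affinity. This change alters the ring attachment and adds the methoxycarbonyl group together, so the step cannot be divided between them. Nothing available explains the gain.

Open, as far as these compounds go, is whether the unsubstituted pyridin-3-yl ring alone accounts for the step. Also open, from the compounds shown here alone, is whether a carboxylic acid in place of the methoxycarbonyl group would hold this level.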